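Amide heteroaryl exchange from compound 3 to compound 4

A few compounds are considered here, and "the series" means these few. Any claim that something is new, unique, unknown or untested is made for them only; others in the source may bear on it.

Measured in an ADME assay on HEK-293T cells (Homo sapiens) for cytotoxicity, read by MTT assay, with a stated time of 72 h, tested at 50 uM; a higher number here means more inhibition at the concentration tested (going by the name of the read-out), a lower number less inhibition:
compound 1 `O=C(Cn1c(-c2ccccc2)cc(-c2ccccc2)c1-c1ccco1)Nc1ccccn1` gives 69.4%
compound 2 `O=C(Cn1c(-c2ccccc2)cc(-c2ccccc2)c1-c1ccccc1)Nc1nc2ccccc2s1` gives 55%
compound 3 `CCc1nnc(NC(=O)Cn2c(-c3ccccc3)cc(-c3ccccc3)c2-c2ccccc2)s1` gives 49.3%

Compound 3 stands lowest of the three numbers in this assay. Its nearest neighbour is compound 2, whose number lies within the scatter of it; compound 1 is furthest, and that gap is beyond the scatter.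

Compound 4 `O=C(Cn1c(-c2ccccc2)cc(-c2ccccc2)c1-c1ccccc1)Nc1ccccn1` differs from compound 3 in one place: pyridin-2-yl in place of 5-ethyl-1,3,4-thiadiazol-2-yl on an amide-type nitrogen.

For the measured compounds named here, the one measured step at the same place is a number 5.7 percentage points lower from compound 2 to compound 3 (within the scatter), an exchange of one heteroaryl for another on the amide-type nitrogen that stayed within the scatter. Going by the values given here, compound 1 carries the same pyridin-2-yl on the amide-type nitrogen as compound 4, but it also differs from compound 3 in its core, so no single step connects them; its value shows only that this amide partner sits with the highest number seen here. On these grounds compound 4 is expected to move somewhat upward from compound 3, a step estimated at a number 7.7 percentage points higher from compound 3 to compound 4 (within the scatter), most likely within the scatter. The estimate for compound 4 in this assay is 57%, with a range from 42% to 72%.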

Compound 4, a percentage reported as inhibition, at one concentration (the size of the read-out at that concentration, not a potency): 62.9%
Beside the measured number, compound 4's estimate is 5.9 percentage points below it; low and high end bracket the measured number.
By their numbers in this assay, from the lowest: compounds 3, 2, 4 and 1 (each within the scatter of the next, the first and the last beyond it).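

Of the three exchanges on the amide-type nitrogen, only a number 13.6 percentage points higher from compound 3 to compound 4 (beyond the scatter) in this assay passes the scatter, which shows that the partner at this position can shift the read-out; a number 7.9 percentage points higher from compound 2 to compound 4 (within the scatter) and a number 5.7 percentage points lower from compound 2 to compound 3 (within the scatter) do not. With pyridin-2-yl held fixed on that nitrogen, phenyl in place of furan-2-yl on an aromatic carbon gives a number 6.5 percentage points lower from compound 1 to compound 4 (within the scatter) and so stays inside the scatter. Nothing available here accounts for any of these steps.

Going by these compounds, whether a partner without an aromatic ring, such as cyclohexyl, or a pyridin-2-yl carrying a carboxylic acid or an amine would hold or shift the number remains open. The single test concentration also leaves the concentration dependence of each compound open.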